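From Hydroxy to Chloro on a Shared Core

A few compounds are considered here, and "the series" means these few. Any claim that something is new, unique, unknown or untested is made for them only; others in the source may bear on it.

Going by the values given here, in an assay for inhibition of Indoleamine 2,3-dioxygenase 1 (Homo sapiens), read by spectrophotometry, with a stated time of 180 min, tested at 10 uM (on this read-out higher numbers stand for a stronger effect at the one concentration tested and lower numbers for a weaker effect), compound 1 `Oc1ccc(CNc2cc(Br)cc3[nH]ncc23)cc1` gives 70%, the highest of the three numbers measured so far. Compound 3 `O=C(O)c1cc(CNc2cc(Br)cc3[nH]ncc23)ccc1O` gives 38% in this assay, and compound 2 `O=C(O)c1ccc(CNc2cccc3[nH]ncc23)cc1` gives 1%. Among the compounds with values here, the only step that changes a single place, a number 32 percentage points lower from compound 1 to compound 3 (beyond the scatter), comes from adding a carboxy group and says nothing about exchanging the hydroxy itself. Compound 4 `Clc1ccc(CNc2cc(Br)cc3[nH]ncc23)cc1` differs from compound 1 by chloro in place of hydroxy on an aromatic carbon. Within the data shown here, no measured step covers this exchange, so the expectation rests on compound 1 alone and is wide. Compound 4 is estimated at 55%, with a range from 20% to 85%. The expected step is a number 15 percentage points lower from compound 1 to compound 4 (beyond the scatter).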

Compound 4, a percentage reported as inhibition, at one concentration (the size of the read-out at that concentration, not a potency): 42%
Compound 4: middle estimate off by 13 percentage points, on the high side; low and high end bracket the measured number.
By their numbers in this assay, from the lowest: compound 2; then compounds 3 and 4 (each within the scatter of the next); then compound 1.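

Going by these compounds alone, exchanging hydroxy for chloro gives a number 28 percentage points lower from compound 1 to compound 4 (beyond the scatter) in this assay, the first look at a change of the hydroxy itself. The effect does not vanish: compound 4, whose chloro has no hydrogen-bond donor or acceptor, still gives 42%, so a measurable effect at this concentration does not require the hydroxy at this place on the shared core. Nothing available explains the drop.

From the compounds shown here alone, how an amine or a methoxy group would behave at this place remains open. With only hydroxy and chloro compared here, the compounds also cannot show whether losing the donor or losing the acceptor matters more.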